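Small carboxylic acids: one methyl added to the core

The source may hold more compounds than are shown below. What is called first, only, known or untested is meant among the compounds shown, and "the series" means these compounds.

Measured so far:
compound 1, `Cc1c[nH]cc1C(=O)O`: 100000 nM
compound 2, `Cc1cc(C(=O)O)c[nH]1`: 100000 nM
compound 3, `Cc1c[nH]c(C)c1C(=O)O`: 100000 nM

In an assay on cells for inhibition of Palmitoleoyl-protein carboxylesterase NOTUM variant C330S (Homo sapiens), read by fluorescence, with a stated time of 40 min (a lower number here means a stronger inhibitor, a higher number a weaker inhibitor), compound 1 gives 100000 nM. Compound 2, `Cc1cc(C(=O)O)c[nH]1`, is built from the same atoms joined differently; the difference between the two cores is not broken down here. In this assay compound 2 gives 100000 nM and compound 3 gives 100000 nM, so all three sit level at the digits shown.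

Among the compounds with values here, the one step measured within this set is methyl in place of hydrogen on an aromatic carbon, which gives no change at the digits printed from compound 1 to compound 3 (within the scatter). Compound 4, `Cc1cc(C(=O)O)c(C)[nH]1`, has not yet been measured. It arises from compound 2 by methyl in place of hydrogen on an aromatic carbon, the same change as that from compound 1 to compound 3, at a place described in the same words.

Within the data shown here, for compound 4 the expected step is no change at the digits printed from compound 2 to compound 4 (within the scatter), resting on the single measured step of no change at the digits printed from compound 1 to compound 3 (within the scatter), which showed nothing at the digits printed. Compound 4 is therefore estimated at 100000 nM, with a range from 30000 nM to 100000 nM.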

Compound 4, half-maximal inhibitory concentration: > 100000 nM
Compound 4: only a limit was reported; the forecaster's own chance of this, stated with the estimate: 60%; the middle value lies on the limit itself.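

In this assay compound 4 gives > 100000 nM, which is a limit of the assay and not a number, so the size of the step from compound 2 cannot be read. Methyl in place of hydrogen on an aromatic carbon gives a number no lower from compound 2 to compound 4 (the limit leaves the size open). Methyl in place of hydrogen on an aromatic carbon can be compared across the two cores only this far: the same change on two cores in this assay, no change at the digits printed (within the scatter) from compound 1 to compound 3 and a number no lower (the limit leaves the size open) from compound 2 to compound 4; the limit leaves it open whether they differ The comparison shows that the methyl gave no lower number on either core, but it does not show that the change carries from one core to the other with the same size, and the reading rests on a single limit: the limit of > 100000 nM in this assay, at which 1 of the 4 values shown sits.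

The compounds shown leave open whether any group on these cores gives a value that can be read as a number in this assay, and so whether the methyl has a measurable effect at all. Also open, as far as these compounds go, is what a longer chain, such as ethyl, or an amine would do at the same place on the ring.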